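The source may hold more compounds than are shown below. What is called first, only, known or untested is meant among the compounds shown, and "the series" means these compounds.

Measured compounds:
compound 1, `NC1CCN(c2c(F)cc3c(=O)c(C(=O)O)cn(C4CC4)c3c2F)CC1`, 23 ug/mL
compound 2, `NC1CCN(c2c(F)cc3c(=O)c(C(=O)O)cn(C4CC4)c3c2C(F)(F)F)CC1`, 20 ug/mL
compound 3, `NC1CCN(c2c(F)c(F)c3c(=O)c(C(=O)O)cn(C4CC4)c3c2F)C1`, 100 ug/mL

The three compounds were tested in a functional assay on V79 cells (Cricetulus griseus) for cytotoxicity, read by colony formation; on this read-out lower numbers stand for stronger inhibition and higher numbers for weaker inhibition. Compound 1 and compound 2 differ by trifluoromethyl in place of fluoro on an aromatic carbon, and the step of a 1.2-fold lower number from compound 1 to compound 2 (0.06 log units; within the scatter). Compound 3 stands on a core that differs from that of compound 1 by more than one change; the difference between the two cores is not broken down here. Compound 3 gives the highest of the three numbers, a gap from compound 1 and compound 2 that lies beyond the usual scatter.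

Compound 4, `NC1CCN(c2c(F)c(F)c3c(=O)c(C(=O)O)cn(C4CC4)c3c2C(F)(F)F)C1`, has not yet been measured. It differs from compound 3 by trifluoromethyl in place of fluoro on an aromatic carbon. This is the same kind of change as that from compound 1 to compound 2, though the surroundings are not the same: here the position is ortho to a 3-aminopyrrolidin-1-yl group and para to a fluoro group, while in compound 1 it was ortho to a 4-aminopiperidin-1-yl group. Because a 1.2-fold lower number from compound 1 to compound 2 (0.06 log units; within the scatter), the expected step is a 1.2-fold lower number from compound 3 to compound 4 (0.07 log units; within the scatter), a change within the scatter. Compound 4 is therefore estimated at 85 ug/mL, with a range from 40 ug/mL to 180 ug/mL.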

Compound 4, half-maximal inhibitory concentration: 190 ug/mL
For compound 4 the middle estimate is 2.2-fold (0.35 log units) below the measured one; the whole stated range lies below it.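

In this assay, trifluoromethyl in place of fluoro gives a 1.9-fold higher number from compound 3 to compound 4 (0.28 log units; within the scatter), so on this second core the swap again stays within the usual scatter of repeated measurements. Set beside the first case, the two steps cannot be told apart: the same change on two cores in this assay, a 1.2-fold lower number (0.06 log units; within the scatter) from compound 1 to compound 2 and a 1.9-fold higher number (0.28 log units; within the scatter) from compound 3 to compound 4, 2.2-fold (0.34 log units) apart, within the scatter of two such steps. This shows that, for these two pairs, the change carries from one core to the other without a step or a gap that rises above the scatter, but it does not show that the step is identical on both cores or that it would hold on any further core.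

The compounds shown carry only fluoro or trifluoromethyl at this place, so it remains open how a chloro group, a methoxy group or a nitrile there would read on either core. Also open, on these data alone, is how the swap would behave with an amine other than the 3-aminopyrrolidin-1-yl and 4-aminopiperidin-1-yl groups, such as a piperazine.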